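Notes on the step from methoxy to propoxy

The compounds below may be only part of what the source reports. "The series", "measured", "known", "first", "only" and "open" are said of these compounds alone.

Measured in an ADME assay on HEK293 cells (Homo sapiens) for cytotoxicity, read by luminescence, with a stated time of 72 h; on this read-out higher numbers stand for an effect only at larger amounts of compound and lower numbers for an effect already at smaller amounts
- compound 1 `CCOC(=O)c1c(-c2cccc(C)c2)[nH]c2cc(OC)ccc2c1=O` gives > 22000 nM (a limit)
- compound 2 `CCOC(=O)c1c(-c2cccc(OC)c2)[nH]c2cc(OC)ccc2c1=O` gives > 22000 nM (a limit)

For compound 2 the value > 22000 nM is a limit and not a number. For the measured compounds named here, the series so far stands at the limit of > 22000 nM in this assay, at which 2 of the 2 values shown sit, and offers no number to compare.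

Compound 3 `CCCOc1cccc(-c2[nH]c3cc(OC)ccc3c(=O)c2C(=O)OCC)c1` differs from compound 2 by ethyl in place of hydrogen on a saturated chain carbon bound to an oxygen on an aromatic ring and so reads as methoxy to propoxy. Going by the values given here, the one measured step bearing on this change is a step that the two limits leave unreadable from compound 1 to compound 2 and it gives no size to carry over. No step beyond the scatter can be argued from it, so in this assay no clear shift in either direction is expected, and a further limit is the likely report. The expected step is a step that the limit leaves unreadable from compound 2 to compound 3 as an estimate only. For compound 3 the estimated value is 30000 nM with an expected range of 15000 nM to 60000 nM (estimate).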

Compound 3, half-maximal effective concentration: > 22000 nM
Compound 3: a limit, no number; the forecaster's own chance of this, stated with the estimate: 80%; the middle value is on the limit's open side.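

No new step can be read among compound 1, compound 2 and compound 3 in this assay, since compound 3 also gives a limit and not a number: the limit of > 22000 nM in this assay, at which 3 of the 3 values shown sit.

The compounds shown leave open how large the methoxy to propoxy step is, and where any of the three would give a number in this assay.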